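Swapping the Carbonyl Substituent on a Shared Thiophene Series

This account rests on a few compounds, and the source may have more. Where it says the series, first, only, none or still open, it means among the compounds named here.

Three compounds sharing one core were tested in an assay on isolated protein for inhibition of protein kinase C zeta type (Homo sapiens), with stated times of 1 h and 2.5 min, tested at 30 uM; on this read-out lower numbers stand for less inhibition and higher numbers for more inhibition at the one concentration tested (going by the name of the read-out). Compound 1, `COCC(C)OC(=O)c1c(-c2ccc(OC)c(OC)c2)csc1N`, gives 49% in this assay. Compound 2, `COc1ccc(-c2csc(N)c2C(=O)OCc2ccc(C)cc2)cc1OC`, gives 50%, so the change a number 1 percentage points higher from compound 1 to compound 2 (within the scatter) left the read-out essentially unchanged. Compound 3, `COc1ccc(-c2csc(N)c2C(=O)OCc2ccc(F)cc2)cc1OC`, gives 2%, the lowest of the three numbers: the step of a number 47 percentage points lower from compound 1 to compound 3 (beyond the scatter) and the step of a number 48 percentage points lower from compound 2 to compound 3 (beyond the scatter) are both large drops.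

Compound 4, `COc1ccc(-c2csc(N)c2C(=O)NCc2ccncc2)cc1OC`, has not yet been measured. It differs from compound 3 in one place: ((pyridin-4-yl)methyl)amino in place of (4-fluorobenzyl)oxy on a carbonyl carbon. The two measured steps that touch this part of the molecule, a number 47 percentage points lower from compound 1 to compound 3 (beyond the scatter) and a number 48 percentage points lower from compound 2 to compound 3 (beyond the scatter), show that small changes to the group on the carbonyl carbon can move the read-out a long way, but neither step exchanges the oxygen attached to the carbonyl for a nitrogen, nor introduces a pyridine ring, so they give only a loose guide. Since compound 3 already sits at the bottom of the range, a further large drop is not possible, while a return toward the values of compound 1 or compound 2 is plausible but uncertain. Compound 4 is therefore expected to give 20%, within a range from 0% to 55%. The expected step is a number 18 percentage points higher from compound 3 to compound 4 (beyond the scatter).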

Compound 4, a percentage reported as inhibition, at one concentration (the size of the read-out at that concentration, not a potency): 3%
Compound 4: the middle estimate sits 17 percentage points above what was measured, within the range that was stated.
By their numbers in this assay, from the lowest: compounds 3 and 4 (each within the scatter of the next); then compounds 1 and 2 (each within the scatter of the next).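

In this assay putting ((pyridin-4-yl)methyl)amino in place of (4-fluorobenzyl)oxy on the carbonyl carbon gave a number 1 percentage points higher from compound 3 to compound 4 (within the scatter) and so left the read-out where it was, even though the linking oxygen became a nitrogen and the carbon-only ring became a ring with a hetero atom. The same group gives a number 47 percentage points lower from compound 2 to compound 4 (beyond the scatter) and a number 46 percentage points lower from compound 1 to compound 4 (beyond the scatter) and so shows that the low reading at this position is not confined to the 4-fluorobenzyl group: two different groups share it, and compound 1 and compound 2 stand well clear of both. Nothing available explains why these groups read so low.

On these data alone, since the nitrogen and the pyridine ring entered together, their separate contributions stay unknown, and a benzylamino group on the same carbonyl carbon, or a (pyridin-4-yl)methoxy group, would pull the two apart. Also open, as far as these compounds go, is how a free carboxylic acid or a simple unsubstituted amide at this position would behave, and whether any group here could take the read-out beyond the level of compound 1 and compound 2.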